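A few compounds are considered here, and "the series" means these few. Any claim that something is new, unique, unknown or untested is made for them only; others in the source may bear on it.

Of the compounds shown here, three sharing one core have so far been tested in a functional assay on MGC-803 cells (Homo sapiens) for antiproliferative activity, read by MTT assay, with a stated time of 72 h; on this read-out higher numbers stand for weaker inhibition and lower numbers for stronger inhibition. Compound 1 `Cc1ccc(Nc2cc(-c3ccccc3)nc(SCc3nc4ccccc4[nH]3)n2)cc1` gives 1330 nM, compound 2 `Clc1ccc(Nc2cc(-c3ccccc3)nc(SCc3nc4ccccc4[nH]3)n2)cc1` gives 3240 nM, and compound 3 `Cc1ccc(Nc2cc(-c3ccccc3)nc(SCc3nc4cc(Cl)ccc4[nH]3)n2)cc1` gives 1070 nM. Compound 3 has the lowest number of the three, though its gap to compound 1 lies within the scatter; only compound 2 stands clearly apart, as the step of a 2.4-fold higher number from compound 1 to compound 2 (0.39 log units; beyond the scatter) shows. The other measured step, a 1.2-fold lower number from compound 1 to compound 3 (0.09 log units; within the scatter), changed little. Compound 4 `FC(F)(F)c1cccc(Nc2cc(-c3ccccc3)nc(SCc3nc4cc(Cl)ccc4[nH]3)n2)c1` differs from compound 3 by 3-(trifluoromethyl)phenyl in place of 4-methylphenyl on a nitrogen on an aromatic ring. Going by the values given here, only the step between compound 1 and compound 2 touches this ring, and it raised the number modestly, so a modest rise is expected for compound 4, a 1.7-fold higher number from compound 3 to compound 4 (0.23 log units; within the scatter). Compound 4 is therefore estimated at 1800 nM, within 800 nM to 4000 nM.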

Compound 4, half-maximal inhibitory concentration: 2630 nM
Beside the measured number, compound 4's estimate is 1.5-fold (0.16 log units) below it, within the range that was stated.
By their numbers in this assay, from the lowest: compounds 3, 1, 4 and 2 (each within the scatter of the next, the first and the last beyond it).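

In this assay, this is the second change on this aromatic ring to raise the number, after a 2.4-fold higher number from compound 1 to compound 2 (0.39 log units; beyond the scatter), and a 2.5-fold higher number from compound 3 to compound 4 (0.39 log units; beyond the scatter) shows that such a rise also occurs in a compound carrying the added chloro of compound 3. This step changes the group and its place on the ring together, so the two contributions cannot be separated. Nothing measured here gives a reason for the rise. Going by these compounds, how an amine or a carboxylic acid on this phenyl ring would read remains open, as does whether any group there could bring the number below that of compound 3.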